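This account rests on a few compounds, and the source may have more. Where it says the series, first, only, none or still open, it means among the compounds named here.

Compound 1, `C=C(C)C(C[C@@H](O)C(=C)C)C[C@@]12C[C@@H](CC=C(C)C)C(C)(C)[C@@](CC=C(C)C)(C(=O)C(C(=O)c3ccc(O)c(O)c3)=C1O)C2=O`: > 10000 nM
Compound 2, `C=C(C)C(C[C@H](O)C(=C)C)C[C@@]12C[C@@H](CC=C(C)C)C(C)(C)[C@@](CC=C(C)C)(C(=O)C(C(=O)c3ccc(O)c(O)c3)=C1O)C2=O`: > 10000 nM

In a functional assay on MDA-MB-231 cells (Homo sapiens) for cytotoxicity, read by MTT assay (on this read-out lower numbers stand for stronger inhibition and higher numbers for weaker inhibition), compound 1 gives > 10000 nM, which is a limit of the assay rather than a number. Compound 2 gives > 10000 nM, also a limit. Compound 2 therefore stands at the limit in this assay, with no measured number to place it. The step that the two limits leave unreadable from compound 1 to compound 2 cannot be read because of the limit of > 10000 nM in this assay, at which 2 of the 2 values shown sit.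

Compound 3, `C=C(C)C(O)C[C@H](C[C@@]12C[C@@H](CC=C(C)C)C(C)(C)[C@@](CC=C(C)C)(C(=O)C(C(=O)c3ccc(O)c(O)c3)=C1O)C2=O)C(=C)C`, has not yet been measured. It differs from compound 2 in this way: the two compounds have the same atoms and bonds; at least one stereo element is drawn with a configuration in one of them and without one in the other: 2 of 5 stereo elements differ; a stereocentre at a saturated chain carbon is drawn S in compound 2 and without a configuration in compound 3; a stereocentre at a saturated chain carbon is drawn without a configuration in compound 2 and S in compound 3. Within the data shown here, the only measured step, from compound 1 to compound 2, is unreadable and so offers no size or direction to carry over; it is the same kind of change, since the fact that one of compounds 1 and 2 is drawn with a defined configuration and the other without, at the place where they differ describes it. Compound 3 is therefore expected to stay at the limit too, its estimated step being a step that the limit leaves unreadable from compound 2 to compound 3. The estimate for compound 3 is 15000 nM, with a range from 7000 nM to 50000 nM.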

Compound 3, half-maximal inhibitory concentration: > 10000 nM
Compound 3: a limit, no number; the forecaster's own chance of this, stated with the estimate: 80%; the middle value lies beyond the limit too.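

The steps among compound 1, compound 2 and compound 3 cannot be read in this assay, as all three sit at the same assay limit: the limit of > 10000 nM in this assay, at which 3 of the 3 values shown sit.

The compounds shown leave open whether the configuration at these saturated chain carbons makes any difference to cytotoxicity on these cells.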